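Compound 2 and an arylamino analogue

A few compounds are considered here, and "the series" means these few. Any claim that something is new, unique, unknown or untested is made for them only; others in the source may bear on it.

Compound 1, `Fc1ccc(CNc2nc(/C=C/c3ccco3)nc3ccsc23)cc1`, in a functional assay on L02 cells (Homo sapiens) for inhibition, read by Griess assay, with stated times of 1 h and 24 h (a lower number here means a stronger inhibitor, a higher number a weaker inhibitor), gives > 1000000 nM, a limit of the assay.
Compound 2, `CNc1nc(/C=C/c2cc(OC)c(OC)c(OC)c2)nc2ccsc12`, in this assay gives > 1000000 nM, likewise a limit.

Compound 2 therefore stands only at a limit, and both values shown sit there (the limit of > 1000000 nM in this assay, at which 2 of the 2 values shown sit). Compound 3, `COc1cc(/C=C/c2nc(Nc3ccc(C)cc3)c3sccc3n2)cc(OC)c1OC`, differs from compound 2 by 4-methylphenyl in place of methyl on a nitrogen on an aromatic ring. Going by the values given here, no measured step covers this change, so in this assay no shift beyond the scatter is expected in either direction, and a limit again seems most likely. The expected step that the limit leaves unreadable from compound 2 to compound 3 is flat. For compound 3 the estimate is 2000000 nM, within 300000 nM to 10000000 nM.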

Compound 3, half-maximal inhibitory concentration: < 40000 nM
Compound 3 gave a limit, no number; the forecaster's own chance of this, stated with the estimate: 85%; middle value at least 50-fold (1.69 log units) away from the limit.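

In this assay, 4-methylphenyl in place of methyl on a nitrogen on an aromatic ring brings an at least 25-fold lower number from compound 2 to compound 3 (1.39 log units; beyond the scatter), the only shift beyond the scatter shown so far, so this position responds to the group it carries. Compound 3 gives < 40000 nM, a limit of the assay. Compound 2 gives > 1000000 nM, also a limit, so the exact size of the step stays unread. As far as these compounds go, whether a plain phenyl or a longer chain such as butyl on that nitrogen would bring the same shift stays open. Compound 1 differs from compound 3 in more than one place and offers no comparison.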